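A few compounds are considered here, and "the series" means these few. Any claim that something is new, unique, unknown or untested is made for them only; others in the source may bear on it.

In a physicochemical assay for solubility, using the shake flask method, in simulated intestinal fluid, measured as kinetic solubility, with a stated time of 2 h, at 25 degrees C, at pH 6.5 (on this read-out higher numbers stand for higher solubility and lower numbers for lower solubility), the measured compounds have so far given no numbers, only limits. Compound 1 `Cc1noc(-c2nc(C)c3c(c2N)C(=O)N(Cc2ccccc2)C3=O)n1` gives < 5000 nM, which is a limit of the assay. Compound 2 `COc1ccc(CN2C(=O)c3c(C)nc(-c4nc(C)no4)c(N)c3C2=O)cc1` gives < 5000 nM, again a limit. Compound 3 `COc1cccc(CN2C(=O)c3c(C)nc(-c4nc(C)no4)c(N)c3C2=O)c1`, the starting point here, gives < 5000 nM, and this too is only a limit. The whole series therefore stands at the limit of < 5000 nM in this assay, at which 3 of the 3 values shown sit.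

Compound 4 `Cc1noc(-c2nc(C)c3c(c2N)C(=O)N(C(C)c2ccccc2)C3=O)n1` keeps the shared core and changes a single group, with 1-phenylethyl in place of 3-methoxybenzyl on an amide-type nitrogen in a ring.

Going by the values given here, three measured steps bear on this group. Methoxy in place of hydrogen on an aromatic carbon gives a step that the two limits leave unreadable from compound 1 to compound 2 and also a step that the two limits leave unreadable from compound 1 to compound 3. Exchanging 4-methoxyphenyl for 3-methoxyphenyl gives a step that the two limits leave unreadable from compound 2 to compound 3. None of these steps has a readable size, so they offer no evidence for a change in either direction. The expectation is therefore no step beyond the usual scatter, with compound 4 most likely reported as a limit again.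

The expected change is a step that the limit leaves unreadable from compound 3 to compound 4. For compound 4 the estimate is 2500 nM, with an expected range from 500 nM to 5000 nM.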

Compound 4, solubility: 10900 nM
For compound 4 the middle estimate is 4.4-fold (0.64 log units) below the measured one; the measured number lies above the stated range.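

The group on the amide-type nitrogen in a ring can carry the read-out of this assay clear of the limit that had kept every earlier comparison from being read: the limit of < 5000 nM in this assay, at which 3 of the 4 values shown sit. Placing 1-phenylethyl in place of a methoxybenzyl group gives an at least 2.1-fold higher number from compound 3 to compound 4 (0.33 log units; beyond the scatter) and an at least 2.1-fold higher number from compound 2 to compound 4 (0.33 log units; beyond the scatter), the first readable steps at this position in the series. The smallest of these changes, methyl in place of hydrogen on the saturated chain carbon bound to the amide-type nitrogen and an aromatic carbon, gives an at least 2.1-fold higher number from compound 1 to compound 4 (0.33 log units; beyond the scatter), so this single added methyl is enough for a readable rise without any change to the aromatic ring.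

Going by these compounds, the steps among compound 1, compound 2 and compound 3 still cannot be read, so the effect of the methoxy group and of where it sits on the ring remains unknown. On these data alone, it also remains open whether an ethyl group in place of the added methyl, or an amine on the same chain carbon, would take the number further in either direction.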